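Moving one fluorine on the lead compound

This account rests on a few compounds, and the source may have more. Where it says the series, first, only, none or still open, it means among the compounds named here.

Compound 1 `COc1ccc(-c2nc(C)oc2C(=O)N2CCN(c3cccc(Cl)c3)CC2)cc1OC`: "not active" (no number reported)
Compound 2 `Cc1nc(-c2ccccc2)c(C(=O)N2CCN(c3cccc(Cl)c3Cl)CC2)o1`: 133 nM
Compound 3 `Cc1nc(-c2ccc(F)cc2)c(C(=O)N2CCN(c3cccc(Cl)c3)CC2)o1`: 40.1 nM

Going by the values given here, in a functional assay on HL-60 cells (Homo sapiens) for inhibition, read by MTT assay, with a stated time of 72 h (a lower number here means a stronger inhibitor, a higher number a weaker inhibitor), compound 3 gives 40.1 nM, the lowest number measured so far. The next number belongs to compound 2 at 133 nM, a gap beyond the usual scatter, while compound 1 gave no number at all. Compound 4 `Cc1nc(-c2cccc(F)c2)c(C(=O)N2CCN(c3cccc(Cl)c3)CC2)o1` has not yet been measured. It carries one change from compound 3: 3-fluorophenyl in place of 4-fluorophenyl on an aromatic carbon, with 3-fluorophenyl in place of 4-fluorophenyl on an aromatic carbon. Among the compounds with values here, no measured pair shows what such a change does in this assay, so only a modest expectation is possible. The expected step is a 1.5-fold higher number from compound 3 to compound 4 (0.18 log units; within the scatter), a slightly weaker result and nothing beyond the scatter. For compound 4 the estimated value is 60 nM, with an expected range of 20 nM to 180 nM.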

Compound 4, half-maximal inhibitory concentration: 33.7 nM
Estimate against measurement, compound 4: 1.8-fold (0.25 log units) above; the range from low to high includes it.
By their numbers in this assay, from the lowest: compounds 4 and 3 (each within the scatter of the next); then compound 2.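

In this assay the move of the fluorine gives a 1.2-fold lower number from compound 3 to compound 4 (0.08 log units; within the scatter) and so leaves the result unchanged within the scatter. Going by these compounds alone, this is the first pair here that differs in one place, and it shows that 3-fluorophenyl and 4-fluorophenyl cannot be told apart at this position on the shared core. No evidence at hand explains this match. The compounds shown leave open whether this phenyl ring needs a fluorine at all. They also leave open whether an amine or a carboxylic acid in its place would keep numbers this low.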